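The compounds below may be only part of what the source reports. "The series", "measured", "known", "first", "only" and "open" are said of these compounds alone.

Compound 2 `C=CC(=O)NCc1coc(-c2c(N)ncnc2Nc2ccc(Oc3cc(Cl)ccc3Cl)c(Cl)c2)n1` gives 0.95 h in an in vitro ADME assay on microsomes from liver (Mus musculus) for metabolic stability, tested at 5 uM; on this read-out higher numbers stand for a longer-lived compound and lower numbers for a shorter-lived compound. Among the three measured compounds it sits alongside compound 1 `C=CC(=O)NCc1coc(-c2c(N)ncnc2Nc2ccc(Oc3ccccc3)c(Cl)c2)n1`, which gives 0.8 h, the pair being within the scatter (a 1.2-fold higher number from compound 1 to compound 2 (0.07 log units; within the scatter)), and apart from compound 3 `C=CC(=O)NCc1coc(-c2c(N)ncnc2Nc2ccc(Oc3ccccn3)c(Cl)c2)n1`, which gives 0.25 h. Compound 4 `C=CC(=O)NCc1coc(-c2c(N)ncnc2Nc2ccc(Oc3cccnc3)c(Cl)c2)n1` differs from compound 2 by pyridin-3-yl in place of 2,5-dichlorophenyl on an oxygen on an aromatic ring. The closest measured guide is a 3.8-fold lower number from compound 2 to compound 3 (0.58 log units; beyond the scatter), and a 3.2-fold lower number from compound 1 to compound 3 (0.51 log units; beyond the scatter) points the same way. A downward step of comparable size is therefore expected in this assay, the estimated step being a 2.7-fold lower number from compound 2 to compound 4 (0.43 log units; beyond the scatter). Compound 4 is accordingly expected to give about 0.35 h, with a range from 0.15 h to 0.8 h.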

Compound 4, half-life: 0.3 h
Beside the measured number, compound 4's estimate is 1.2-fold (0.07 log units) above it; low and high end bracket the measured number.
By their numbers in this assay, from the lowest: compounds 3 and 4 (each within the scatter of the next); then compounds 1 and 2 (each within the scatter of the next).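

In this assay, pyridin-3-yl groups with pyridin-2-yl rather than with the rings of carbon only: a 1.2-fold higher number from compound 3 to compound 4 (0.08 log units; within the scatter) stays within the scatter, while a 3.2-fold lower number from compound 2 to compound 4 (0.50 log units; beyond the scatter) and a 2.7-fold lower number from compound 1 to compound 4 (0.43 log units; beyond the scatter) lie beyond it. Across these four compounds, then, a ring nitrogen on the aryloxy group goes with the lower numbers wherever it sits in the two pyridines, and no compound goes against this. No measured finding accounts for the pattern. Still open, from the compounds shown here alone, is whether a pyridin-4-yl group would follow the same pattern, and whether chlorine on the pyridine ring would restore the higher numbers.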